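Extending the Nitrogen Substituent of Compound 2

This account rests on a few compounds, and the source may have more. Where it says the series, first, only, none or still open, it means among the compounds named here.

Compound 2 `Cn1sc2cc(OCc3cccc(-c4ccc(Cl)c(C(=O)O)c4)c3)ccc2c1=O` is the only one of the three measured compounds that gives an actual number in an assay on HEK293 cells for positive allosteric modulation of metabotropic glutamate receptor 2 (Rattus norvegicus), read by thallium flux; on this read-out lower numbers stand for an effect already at smaller amounts and higher numbers for an effect only at larger amounts of compound: compound 2 gives 640 nM. Compound 1 `O=C1c2ccc(OCc3cccc(-c4ccc(Cl)cc4F)c3)cc2CN1C1CCCC1` gives only a limit in this assay, namely > 5000 nM. Compound 3 `O=C1c2ccc(OCc3cccc(-c4ccc(C(F)(F)F)cc4F)c3)cc2CN1C1CCCC1` likewise gives only a limit, > 5000 nM. For the measured compounds named here, the single measured step, a step that the two limits leave unreadable from compound 1 to compound 3, runs between two limits, and the evidence on it is the limit of > 5000 nM in this assay, at which 2 of the 3 values shown sit. Compound 4 `CC(C)CCn1sc2cc(OCc3cccc(-c4ccc(Cl)c(C(=O)O)c4)c3)ccc2c1=O` differs from compound 2 by isobutyl in place of hydrogen on a saturated chain carbon bound to an aromatic nitrogen. Going by the values given here, no measured step touches the saturated chain carbon bound to an aromatic nitrogen, and the one step that exists, from chloro to trifluoromethyl on an aromatic carbon, cannot be read in size. Among the compounds with values here, nothing among the measured compounds therefore points in either direction for this change. In this assay the step from compound 2 to compound 4 is expected to remain within the usual scatter, a 1.2-fold lower number from compound 2 to compound 4 (0.07 log units; within the scatter). Compound 4 is estimated at 550 nM, with a range from 150 nM to 2500 nM.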

Compound 4, half-maximal effective concentration: 650 nM
Compound 4: the middle estimate sits 1.2-fold (0.07 log units) below what was measured, and the stated range covers the measured number.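

In this assay, the first step readable in size runs a 1.0-fold higher number from compound 2 to compound 4 (0.01 log units; within the scatter), so this place on the saturated chain carbon bound to an aromatic nitrogen takes an isobutyl group, with its 4 heavy atoms, without moving the number beyond the scatter. For the compounds shown here, the earlier compounds showed nothing about this place, and their one step concerned a different change and could not be read, so this is the first direct reading for the extended chain, though it rests on this single pair. None of the measurements shown gives a reason for this outcome.

Going by these compounds, it remains open whether a longer chain, a ring or an amine at the end of the chain would also stay within the scatter. On these data alone, it is also open whether the same change would read alike on another core or in another assay.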